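Swapping Methyl for Bromo in a Three-Compound Series

This account rests on a few compounds, and the source may have more. Where it says the series, first, only, none or still open, it means among the compounds named here.

Compound 3 `Cc1ccc(-c2cc3nc(-c4ccc(Cl)cc4)cc(N)n3n2)cc1` stands highest of the three compounds in a functional assay on the whole organism (strain Wistar) for inhibition, with Rattus norvegicus as the target, read by paw edema, with stated times of 30 min and 1 h, at a dose of 50 mg/kg by the oral route (on this read-out higher numbers stand for more inhibition at the one dose given (going by the name of the read-out) and lower numbers for less inhibition), where compound 3 reaches 59.6%. Compound 1 `Cc1ccc(-c2cc3nc(-c4ccc(F)cc4)cc(N)n3n2)cc1` gives 28.8%, and compound 2 `Nc1cc(-c2ccc(Cl)cc2)nc2cc(-c3ccccc3)nn12` gives 21.2%. Compound 4 `Nc1cc(-c2ccc(Cl)cc2)nc2cc(-c3ccc(Br)cc3)nn12` differs from compound 3 by bromo in place of methyl on an aromatic carbon. Going by the values given here, two measured steps bear on this change. The step of a number 38.4 percentage points higher from compound 2 to compound 3 (beyond the scatter) shows a large gain when a methyl replaces hydrogen at this same position, while the step of a number 30.8 percentage points higher from compound 1 to compound 3 (beyond the scatter) shows a large gain from a heavier halogen elsewhere on the shared core. Because the step of a number 38.4 percentage points higher from compound 2 to compound 3 (beyond the scatter) shows the gain that came with the methyl compound 4 no longer carries, while a halogen enters in its place, a moderate loss is expected: a number 14.6 percentage points lower from compound 3 to compound 4 (beyond the scatter). Compound 4 is therefore estimated at 45%, with a likely range from 20% to 70%.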

Compound 4, a percentage reported as inhibition, in the whole organism at one dose (the size of the read-out at that dose, not a potency): 13.5%
Beside the measured number, compound 4's estimate is 31.5 percentage points above it; measured number outside the range, below it.
By their numbers in this assay, from the lowest: compounds 4, 2 and 1 (each within the scatter of the next, the first and the last beyond it); then compound 3.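

The change to bromo gives a number 46.1 percentage points lower from compound 3 to compound 4 (beyond the scatter) and so does not keep the gain seen with methyl. Set against hydrogen, bromo gives a number 7.7 percentage points lower from compound 2 to compound 4 (within the scatter) and the two cannot be told apart, so of the three groups compared at this place on the ring, only methyl lifts the number. Nothing available explains why methyl and bromo differ so widely here. Still open, as far as these compounds go, is whether a longer chain such as ethyl would keep the gain seen with methyl, and whether a methoxy group or an amine at this place would read closer to methyl or to bromo.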